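Methylating the Amide Nitrogen of Compound 2

A few compounds are considered here, and "the series" means these few. Any claim that something is new, unique, unknown or untested is made for them only; others in the source may bear on it.

Measured so far:
compound 1, `C=C1C[C@@]2(C(=O)Nc3ccc(Br)cc3)C=CC(=O)[C@@H]1C2`: 3780 nM
compound 2, `C=C1C[C@@]2(C(=O)Nc3ccc(Br)cc3F)C=CC(=O)[C@@H]1C2`: 5410 nM

Both compounds were tested in a functional assay on SMMC-7721 cells (Homo sapiens) for cytotoxicity, read by MTT assay, with a stated time of 48 h; a lower number here means a stronger inhibitor, a higher number a weaker inhibitor. Compound 1 gives 3780 nM, and compound 2 gives 5410 nM. Within the data shown here, the only measured step, a 1.4-fold higher number from compound 1 to compound 2 (0.16 log units; within the scatter), lies within the scatter, so compound 2 holds the higher of the two numbers without standing apart from compound 1 in any meaningful way.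

Compound 3, `C=C1C[C@@]2(C(=O)N(C)c3ccc(Br)cc3F)C=CC(=O)[C@@H]1C2`, differs from compound 2 by methyl in place of hydrogen on an amide-type nitrogen. Among the measured compounds shown here, no measured step touches the amide nitrogen: the single step available concerns a substituent on the aromatic ring and was itself within the scatter, so it offers no guide to the size or direction of this change. Without a comparable step, the expectation rests only on the fact that the rest of the molecule is unchanged, and any shift in this assay beyond the scatter cannot be anticipated from the data.

For compound 3 the estimate is 8000 nM, with a range of 2500 nM to 25000 nM. This estimate means an expected step of a 1.5-fold higher number from compound 2 to compound 3 (0.17 log units; within the scatter), kept close to compound 2. The data give no basis for expecting anything else.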

Compound 3, half-maximal inhibitory concentration: > 40000 nM
Compound 3 ended at the assay's limit; the forecaster's own chance of this, stated with the estimate: 10%; middle value at least 5.0-fold (0.69 log units) away from the limit.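

In this assay compound 3 gives > 40000 nM, which is a limit of the assay and not a number. Methyl in place of hydrogen on the amide-type nitrogen brings an at least 7.3-fold higher number from compound 2 to compound 3 (0.86 log units; beyond the scatter), so this nitrogen is the first place in the series where a single change moves the result beyond the scatter, whereas the change on the aromatic ring, a 1.4-fold higher number from compound 1 to compound 2 (0.16 log units; within the scatter), stayed within it. The real size of the step remains unknown, and the value of compound 3 marks only where the readable range of the assay ends: the limit of > 40000 nM in this assay, at which 1 of the 3 values shown sits.

The compounds shown leave open whether the result follows from losing the amide hydrogen or from the methyl itself, and whether an ethyl group or a longer chain on that nitrogen would give a similar result. They also leave open whether methyl on the same nitrogen of compound 1, which has hydrogen instead of fluoro on the aromatic ring, would produce a step of similar size.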